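Changing the piperidinylmethyl group of compound 1

A few compounds are considered here, and "the series" means these few. Any claim that something is new, unique, unknown or untested is made for them only; others in the source may bear on it.

In a functional assay on HCT-116 cells (Homo sapiens) for antiproliferative activity, read by sulforhodamine B assay (a lower number here means a stronger inhibitor, a higher number a weaker inhibitor), three compounds sharing one core have been measured. Compound 1 `O=C1NC(=O)c2ccc(I)cc2/C1=C/Nc1ccc(CN2CCCCC2)cc1` gives 2700 nM, compound 2 `O=C1NC(=O)c2ccc(-n3cccc3)cc2/C1=C/Nc1ccc(CN2CCCCC2)cc1` gives 2700 nM and compound 3 `O=C1NC(=O)c2ccc(-c3ccoc3)cc2/C1=C/Nc1ccc(CN2CCCCC2)cc1` gives 1900 nM. Compound 1 therefore stands level with compound 2 and within the scatter of compound 3.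

Compound 4 `C[C@@H]1CN(c2ccc(N/C=C3\C(=O)NC(=O)c4ccc(I)cc43)cc2)[C@@H](C)CN1C` keeps the iodo group of compound 1 but alters the other substituent: 2,4,5-trimethylpiperazin-1-yl in place of (piperidin-1-yl)methyl on an aromatic carbon. The measured steps all concern the iodo group or its replacements. They are no change at the digits printed from compound 1 to compound 2 (within the scatter), a 1.4-fold lower number from compound 1 to compound 3 (0.15 log units; within the scatter) and a 1.4-fold lower number from compound 2 to compound 3 (0.15 log units; within the scatter), each within the scatter. Among the measured compounds shown here, none of them touches the (piperidin-1-yl)methyl group, so they offer no direct measure of this change and show only that exchanges at the other site left the numbers within the scatter. For the measured compounds named here, with no measured step at this place, no firm direction can be given, and a shift beyond the scatter is not expected. The estimated change is a 1.4-fold lower number from compound 1 to compound 4 (0.13 log units; within the scatter). For compound 4 the expected value is 2000 nM, with an estimated range from 700 nM to 6000 nM.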

Compound 4, half-maximal inhibitory concentration: 5000 nM
The estimate for compound 4 lay 2.5-fold (0.40 log units) below the measured number; low and high end bracket the measured number.
By their numbers in this assay, from the lowest: compounds 3, 1, 2 and 4 (each within the scatter of the next, the first and the last beyond it).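

In this assay, among the compounds shown here, the first measured change at this position gives a 1.9-fold higher number from compound 1 to compound 4 (0.27 log units; within the scatter), so the replacement of (piperidin-1-yl)methyl by 2,4,5-trimethylpiperazin-1-yl stays within the scatter. Exchanges at the iodo site had already shown this for that site, and the same now holds on this side of the molecule, even with a larger group that has 2 hetero atoms in its ring and 2 defined stereocentres. No supporting data bear on this step, so the result stands without an explanation.

The compounds shown leave open what a plain piperazine without methyl groups, or a morpholine, would give at this place on the core of compound 1. They also leave open whether 2,4,5-trimethylpiperazin-1-yl would give a similar number when paired with furan-3-yl instead of iodo.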